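The source may report more compounds than this note shows. Statements on the series, on what has been measured and on what is new or still open speak of the compounds shown alone.

Measured in a physicochemical assay for lipophilicity, at pH 7.4; on this read-out lower numbers stand for lower lipophilicity and higher numbers for higher lipophilicity:
- compound 1 `CCn1nc(CC(=O)Nc2ccc(OC(F)(F)F)c(Cl)c2)c2ccccc2c1=O`: 5.42
- compound 2 `C[C@@H](C(=O)O)c1nn(Cc2cn3cc(OCC4CC4)c(Cl)cc3n2)c2ccccc2c1=O`: 2.41

Of these two, compound 1 stands highest, and compound 2, at 2.41, lies lower by a gap well beyond the scatter. Compound 3 `O=C(Cc1nn(C2CCNC2)c(=O)c2ccccc12)Nc1ccc(OC(F)(F)F)c(Cl)c1` has not yet been measured in this assay. It carries pyrrolidin-3-yl in place of ethyl on an aromatic nitrogen. Among the measured compounds shown here, no measured pair of compounds differs in only one place, so the expectation rests on this structural change alone. A large downward move is expected, estimated as a number 1.92 log units lower from compound 1 to compound 3 (beyond the scatter). Compound 3 is expected at 3.5, with an estimated range from 2.7 to 4.3.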

Compound 3, distribution coefficient: 3.03
Compound 3: the middle estimate sits 0.47 log units above what was measured; the range from low to high includes it.
By their numbers in this assay, from the lowest: compound 2; then compound 3; then compound 1.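

Putting pyrrolidin-3-yl in place of ethyl on the aromatic nitrogen gives, in this assay, a number 2.39 log units lower from compound 1 to compound 3 (beyond the scatter) and this is the first step shown with the rest of the molecule unchanged. It shows that this one position, with the anilide side of compound 1 kept intact, can by itself carry a large change in the read-out. Nothing measured here explains the size of the step. The compounds shown leave open whether the step follows the ring or its nitrogen; a cyclopentyl ring or an open-chain aminoethyl group at this position would separate the two.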